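The source may report more compounds than this note shows. Statements on the series, on what has been measured and on what is new or still open speak of the compounds shown alone.

Compound 3 `CN1CC(NC(=O)c2cc(-c3ccc(NS(=O)(=O)c4cccc(Cl)c4Cl)cc3)nc3[nH]ncc23)C1` bears a 1-methylazetidin-3-yl group on its amide-type nitrogen. In an assay for inhibition of serine/threonine-protein kinase Sgk1 (Homo sapiens), with stated times of 30 min and 60 min, in the presence of a further agent that is not named here (a higher number here means a weaker inhibitor, a lower number a stronger inhibitor), compound 3 reaches a limit of the assay, < 1 nM. Compound 2 `CN(C)CCCNC(=O)c1cc(-c2ccc(NS(=O)(=O)c3cccc(Cl)c3Cl)cc2)nc2[nH]ncc12` gives 633 nM in this assay, and the step of an at least 630-fold lower number from compound 2 to compound 3 (2.80 log units; beyond the scatter) is the only sized step shown. Compound 1 `CCNC(=O)c1cc(-c2ccc(NS(=O)(=O)c3cccc(Cl)c3Cl)cc2)nc2[nH]ncc12` reaches a limit as well, < 1920 nM. The steps a step that the limit leaves unreadable from compound 1 to compound 2 and a step that the two limits leave unreadable from compound 1 to compound 3 stay unreadable because the limit of < 1920 nM in this assay, at which 1 of the 3 values shown sits, and the limit of < 1 nM in this assay, at which 1 of the 3 values shown sits, sit at their ends. Compound 4 `CCN1CCC(CNC(=O)c2cc(-c3ccc(NS(=O)(=O)c4cccc(Cl)c4Cl)cc3)nc3[nH]ncc23)C1` differs from compound 3 by (1-ethylpyrrolidin-3-yl)methyl in place of 1-methylazetidin-3-yl on an amide-type nitrogen. Since the step of an at least 630-fold lower number from compound 2 to compound 3 (2.80 log units; beyond the scatter) was large, this change at the same position is expected to cost some potency, a moderate rise an at least 6.0-fold higher number from compound 3 to compound 4 (0.77 log units; beyond the scatter). Compound 4 is therefore estimated at 6 nM, with a range from 0.8 nM to 60 nM.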

Compound 4, half-maximal inhibitory concentration: 109 nM
Compound 4: the middle estimate sits 18-fold (1.26 log units) below what was measured; measured number outside the range, above it.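

In this assay, (1-ethylpyrrolidin-3-yl)methyl in place of 1-methylazetidin-3-yl on the amide-type nitrogen gives an at least 100-fold higher number from compound 3 to compound 4 (2.03 log units; beyond the scatter), so a ring-bearing group at this position does not by itself keep the number low. Compared with the 3-(dimethylamino)propyl group, the same group gives a 5.8-fold lower number from compound 2 to compound 4 (0.76 log units; beyond the scatter), a far smaller drop than compound 3 shows. The step from compound 1 to compound 4 cannot be read because compound 1 stands at a limit: the limit of < 1920 nM in this assay, at which 1 of the 4 values shown sits.

The change swaps ring size, adds a carbon link and puts ethyl for methyl all at once, and the compounds shown leave open which of these carries the rise. A 1-methylpyrrolidin-3-yl group or a (1-methylazetidin-3-yl)methyl group would separate them.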